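A few compounds are considered here, and "the series" means these few. Any claim that something is new, unique, unknown or untested is made for them only; others in the source may bear on it.

Measured compounds:
Compound 1, `NC(=O)c1c(NC(=O)c2ccccc2Cl)sc2c1CCN(Cc1ccc(Cl)cc1)C2`: in a functional assay on MKN-74 cells (Homo sapiens) for antiproliferative activity, with a stated time of 24 h (a higher number here means a weaker inhibitor, a lower number a stronger inhibitor), compound 1 gives 18700 nM.
Compound 2, `NC(=O)c1c(NC(=O)c2ccccc2Cl)sc2c1CCN(Cc1ccc([N+](=O)[O-])cc1)C2`: compound 2 gives 31500 nM.
Compound 3, `NC(=O)c1c(NC(=O)c2ccccc2Cl)sc2c1CCN(Cc1ccc(Cl)cc1Cl)C2`: compound 3 gives 16300 nM.

Compound 3 has the lowest of the three numbers, but it is not separated from the others: a 1.1-fold lower number from compound 1 to compound 3 (0.06 log units; within the scatter) and a 1.9-fold lower number from compound 2 to compound 3 (0.29 log units; within the scatter) both fall within the scatter, as does a 1.7-fold higher number from compound 1 to compound 2 (0.23 log units; within the scatter). All three measured steps swap one group on the ring nitrogen of the shared core for another, and none of them moves the number beyond the scatter.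

Compound 4, `NC(=O)c1c(NC(=O)c2ccccc2Cl)sc2c1CCN(C(=S)Nc1ccccc1Br)C2`, continues this series at the same position, with a group of 10 heavy atoms (7 carbon, 1 nitrogen, 1 sulfur, 1 bromine; one six-membered aromatic ring of carbon only) in place of a group of 9 heavy atoms (7 carbon, 2 chlorine; one six-membered aromatic ring of carbon only), on an amine nitrogen in a ring. The change is larger than any measured one, since the entering group brings a hydrogen-bond donor and acceptor and a double bond outside the aromatic ring, while every measured step exchanged one substituted benzyl for another. Among the measured compounds shown here, no measured pair shows what such a linkage does here. Because the three steps on record, a 1.7-fold higher number from compound 1 to compound 2 (0.23 log units; within the scatter), a 1.1-fold lower number from compound 1 to compound 3 (0.06 log units; within the scatter) and a 1.9-fold lower number from compound 2 to compound 3 (0.29 log units; within the scatter), all stay within the scatter, the expectation for compound 4 is a step of a 1.0-fold lower number from compound 3 to compound 4 (0.01 log units; within the scatter), that is, none beyond the scatter, with a wider range to allow for the untested linkage. Compound 4 is estimated at 16000 nM, between 4500 nM and 55000 nM.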

Compound 4, half-maximal inhibitory concentration: 10800 nM
For compound 4 the middle estimate is 1.5-fold (0.17 log units) above the measured one; the range from low to high includes it.
By their numbers in this assay, from the lowest: compounds 4, 3, 1 and 2 (each within the scatter of the next, the first and the last beyond it).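

Compound 4 shows that the amine nitrogen in a ring of the shared core can carry a group other than a substituted benzyl without leaving the range of the benzyl compounds in this assay. Among the compounds shown here, although the entering group brings a hydrogen-bond donor, a hydrogen-bond acceptor and a double bond outside aromatic rings, a 1.5-fold lower number from compound 3 to compound 4 (0.18 log units; within the scatter) and a 1.7-fold lower number from compound 1 to compound 4 (0.24 log units; within the scatter) remain small, while a 2.9-fold lower number from compound 2 to compound 4 (0.46 log units; beyond the scatter) is the first step to pass beyond the scatter, and it is modest in size. Nothing at hand accounts for any of these steps.

The compounds shown leave open how much of the result belongs to the linkage and how much to the bromine on the aromatic ring, since both enter together with compound 4. Also open, on these data alone, is what happens at this nitrogen with a urea linkage, carrying oxygen in place of the sulfur, or with a carboxylic acid or a pyridine ring on the entering group.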